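A few compounds are considered here, and "the series" means these few. Any claim that something is new, unique, unknown or untested is made for them only; others in the source may bear on it.

Measured compounds:
- compound 1, `Oc1ccc(-c2cc(-c3cccnc3)nc(-c3ccccc3Cl)c2)cc1`: in an ADME assay on HEK293 cells (Homo sapiens) for cytotoxicity, read by CCK-8 assay and cell counting, with a stated time of 2 days (on this read-out lower numbers stand for stronger inhibition and higher numbers for weaker inhibition), compound 1 gives "not determined" (no result reported)
- compound 2, `Oc1ccc(-c2cc(-c3ccccc3)nc(-c3ccccc3Cl)c2)cc1`: compound 2 gives 3930 nM
- compound 3, `Oc1ccc(-c2cc(-c3cccs3)nc(-c3ccccc3Cl)c2)cc1`: compound 3 gives 5220 nM

Compound 1 therefore stands without a number in this assay; only compounds 2 and 3 give values, and those two lie close together. Compound 4, `Oc1ccc(-c2cc(-c3cccnc3)nc(-c3cccc(Cl)c3)c2)cc1`, differs from compound 1 by 3-chlorophenyl in place of 2-chlorophenyl on an aromatic carbon. Within the data shown here, the one measured step, a 1.3-fold higher number from compound 2 to compound 3 (0.12 log units; within the scatter), concerns a change at a different aromatic carbon and lay within the scatter, so no step in the data touches the chlorophenyl group itself. The expectation can only be anchored to the values of compounds 2 and 3, which share the rest of the framework, and no step beyond the scatter is expected. Compound 4 is therefore estimated at about 4500 nM, with a range from 1500 nM to 15000 nM.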

Compound 4, half-maximal inhibitory concentration: 25700 nM
Estimate against measurement, compound 4: 5.7-fold (0.76 log units) below; measured number outside the range, above it.
By their numbers in this assay, from the lowest: compounds 2 and 3 (each within the scatter of the next); then compound 4.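

Among these compounds, compound 1 has no number in this assay and so no step from it to compound 4 can be read. From the compounds shown here alone, what 3-chlorophenyl in place of 2-chlorophenyl does on this shared core stays open. Nothing measured here bears on the result of compound 4.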